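Swapping a Methyl for Chloro on the Benzyl Ring

The compounds below may be only part of what the source reports. "The series", "measured", "known", "first", "only" and "open" are said of these compounds alone.

Of the compounds shown here, two sharing one core have been measured in an assay on isolated protein for inhibition of Dihydrofolate reductase (Mus musculus); on this read-out lower numbers stand for lower potency and higher numbers for higher potency (the scale is a negative logarithm). Compound 1, with the structure `Cc1cc(S(=O)(=O)F)ccc1COc1ccc(N2C(N)=NC(N)=NC2(C)C)cc1Cl`, gives 7.38. Compound 2, with the structure `CC1(C)N=C(N)N=C(N)N1c1ccc(OCc2cccc(S(=O)(=O)F)c2Cl)c(Cl)c1`, gives 7.49. These two numbers lie within the scatter of this assay, so compound 1 and compound 2 cannot be told apart; compound 1 simply carries the lower of the two numbers shown.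

The compound still to be measured is compound 3, with the structure `CC1(C)N=C(N)N=C(N)N1c1ccc(OCc2ccc(S(=O)(=O)F)cc2Cl)c(Cl)c1`. It differs from compound 1 in one place: chloro in place of methyl on an aromatic carbon. The change sits on an aromatic carbon of a six-membered aromatic ring of carbon only, ortho to a large group and meta to a fluorosulfonyl group.

For the measured compounds named here, no measured pair shows exactly this swap, so the step is open. Since both measured compounds carry chloro on a benzyl ring and land close together, the change is expected to move this assay little, with a step of a number 0.12 log units higher from compound 1 to compound 3 (within the scatter) not beyond the scatter. Compound 3 is therefore estimated at 7.5, within a range from 7 to 8.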

Compound 3, logarithm of the reciprocal of the active concentration, log(1/C): 7.44
For compound 3 the middle estimate is 0.06 log units above the measured one; measured number inside the range.
By their numbers in this assay, from the lowest: compounds 1, 3 and 2 (each within the scatter of the next).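

In this assay, chloro in place of methyl on this aromatic carbon, ortho to a large group and meta to a fluorosulfonyl group, gives a number 0.06 log units higher from compound 1 to compound 3 (within the scatter). This is a direct reading of the swap at this one place, which the earlier pair of compounds could not provide, and it shows that the two groups cannot be told apart here in this assay. No measurement in hand accounts for this result, so the finding stands as an observation without an explanation.

Methyl and chloro each count only 1 heavy atom, so the compounds shown say nothing about how this assay would respond to a larger or very different group on this carbon, such as an amine, a carboxylic acid or a longer chain. They also leave open whether the same swap would read alike on a core without the fluorosulfonyl group, or in any read-out other than this assay.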